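The source may report more compounds than this note shows. Statements on the series, on what has been measured and on what is new or still open speak of the compounds shown alone.

Measured so far:
- compound 1 `Cc1ccc(CSc2nc3nc(C)cc(Nc4cc(-c5ccccc5)[nH]n4)n3n2)cc1`: 7290 nM
- compound 2 `Cc1cc(Nc2cc(-c3ccc(F)cc3)[nH]n2)n2nc(SCc3ccc(Br)cc3)nc2n1`: 4570 nM

In a functional assay on MCF7 cells (Homo sapiens) for inhibition, read by MTT assay, with a stated time of 72 h (a lower number here means a stronger inhibitor, a higher number a weaker inhibitor), compound 1 gives 7290 nM. In this assay compound 2 gives 4570 nM. Compound 1 holds the higher of the two numbers, but its nearest neighbour, compound 2, sits within the scatter of it, so the two cannot be ordered against each other. Among the measured compounds shown here, no pair of measured compounds differs at only one place, so no measured step is available to guide the next change.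

Compound 3 `CCCSc1nc2nc(C)cc(Nc3cc(-c4ccccc4)[nH]n3)n2n1` has not yet been measured in this assay. It comes from compound 1 by the change (ethyl in place of 4-methylphenyl on a saturated chain carbon bound to a sulfur). For the measured compounds named here, with no comparable step, the direction of this step is uncertain; the expectation is a small step toward a higher number in this assay, of a size that might also fall within the scatter, so the estimated step is a 1.6-fold higher number from compound 1 to compound 3 (0.22 log units; within the scatter). For compound 3 the expected value in this assay is 12000 nM, with a range from 4000 nM to 40000 nM.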

Compound 3, half-maximal inhibitory concentration: > 50000 nM
Compound 3 gave a limit, no number; the forecaster's own chance of this, stated with the estimate: 20%; at least 4.1-fold (0.61 log units) between middle value and limit.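

In this assay compound 3 gives > 50000 nM, which is a limit of the assay and not a number. The place on a saturated chain carbon bound to a sulfur now has its first measured step, and the group there matters in this assay: ethyl in place of 4-methylphenyl gives an at least 6.8-fold higher number from compound 1 to compound 3 (0.83 log units; beyond the scatter). This step fixes a direction, but its size is bounded on one side only: the limit of > 50000 nM in this assay, at which 1 of the 3 values shown sits.

The change from 4-methylbenzyl to propyl removes the six-membered aromatic ring and also reduces the heavy atoms of the group, so the compounds shown cannot separate these two differences. On these data alone, a cyclohexylmethyl group or a longer chain such as hexyl on the same sulfur would bear on that question, and it also remains open whether an amine at the end of such a chain would be tolerated at this place in this assay.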